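The source may report more compounds than this note shows. Statements on the series, on what has been measured and on what is new or still open speak of the compounds shown alone.

Of the compounds shown here, three have been tested in a functional assay on L1210 (1565) cells (Mus musculus) for cytotoxicity (a lower number here means that less compound is needed, a higher number that more compound is needed for the effect), so far. Compound 1 `COc1ccc2nc(-c3ccccc3)cc(O)c2c1` gives 0.06 ug/mL in this assay. Compound 2 `COCOc1ccc(-c2cc(=O)c3ccccc3n2C)cc1` reaches only the limit of the measurement, reported as > 10 ug/mL, so no number is known for it. Compound 3 `Oc1cc(-c2ccccc2)nc2c(O)cccc12` likewise stops at the limit, reported as > 10 ug/mL. Compound 2 therefore stands together with compound 3 at the limit of > 10 ug/mL in this assay, at which 2 of the 3 values shown sit, while compound 1 is the only one of the three with a measured number. Among the measured compounds shown here, none of these pairs differs in one place only, so no single step between measured compounds can be read off.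

Compound 4 `Cn1c(-c2ccc(O)cc2)cc(=O)c2ccccc21` has not yet been measured. It is related to compound 2 by one change, (hydrogen in place of methoxymethyl on an oxygen on an aromatic ring). The two share the whole of the rest of their structure. For the measured compounds named here, because compound 2 sits at > 10 ug/mL, only the direction away from the limit can be seen at all, and no measured step tells how large such a change is here. Compound 4 is expected to move from the limit toward a measurable number, with a step of about an at least 3.3-fold lower number from compound 2 to compound 4 (0.52 log units; beyond the scatter). Compound 4 is estimated to give 3 ug/mL in this assay, within a range from 0.3 ug/mL to 10 ug/mL.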

Compound 4, half-maximal effective concentration: > 10 ug/mL
Compound 4 ended at the assay's limit (the forecaster's own chance of this, stated with the estimate: 40%); at least 3.3-fold (0.52 log units) between middle value and limit.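

Among the compounds shown here, no step from compound 2 to compound 4 can be read in this assay, because both compounds stop at the same limit and neither has a number: the limit of > 10 ug/mL in this assay, at which 3 of the 4 values shown sit. The compounds shown leave open whether hydrogen in place of methoxymethyl on an oxygen on an aromatic ring changes the amount of compound needed at all, and by how much.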